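Working notes: from compound 2 to compound 3

The compounds below may be only part of what the source reports. "The series", "measured", "known", "first", "only" and "open" are said of these compounds alone.

- compound 1 `O=C(Nc1ccc2c(c1)CCN2c1ccc(C(=O)NO)cc1)Nc1ccc(Cl)c(C(F)(F)F)c1` at 4100 nM
- compound 2 `O=C(/C=C/c1ccc(CN2CCc3cc(NC(=O)Nc4ccc(Cl)c(C(F)(F)F)c4)ccc32)cc1)NO` at 3500 nM

Both numbers come from a functional assay on SK-HEP1 cells (Homo sapiens) for inhibition, read by sulforhodamine B assay, with a stated time of 48 h (a higher number here means a weaker inhibitor, a lower number a stronger inhibitor), and lie within the usual scatter of each other, so compound 2 stands level with compound 1 and the two cannot be ranked. The next compound, compound 3 `O=C(Nc1ccc2c(c1)CCN2Cc1ccc(C(=O)NO)cc1)Nc1ccc(Cl)c(C(F)(F)F)c1`, differs from compound 2 in one place, by hydroxycarbamoyl in place of 2-(hydroxycarbamoyl)ethenyl on an aromatic carbon on an aromatic carbon, with 4-(hydroxycarbamoyl)phenyl replacing 4-(2-(hydroxycarbamoyl)ethenyl)phenyl. Going by the values given here, no measured pair isolates this change. Compound 1 with 4100 nM carries the entering 4-(hydroxycarbamoyl)phenyl, and compound 2 with 3500 nM carries the leaving group, so no shift beyond the scatter is expected in this assay on this evidence. The estimated size of a 1.1-fold lower number from compound 2 to compound 3 (0.04 log units; within the scatter) stays within the scatter, and no direction is expected. Compound 3 is estimated at 3200 nM (expected range 1300 nM to 8000 nM).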

Compound 3, half-maximal inhibitory concentration: 4600 nM
Beside the measured number, compound 3's estimate is 1.4-fold (0.16 log units) below it; low and high end bracket the measured number.
By their numbers in this assay, from the lowest: compounds 2, 1 and 3 (each within the scatter of the next).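

Going by these compounds alone, the step to hydroxycarbamoyl in place of 2-(hydroxycarbamoyl)ethenyl on an aromatic carbon gives a 1.3-fold higher number from compound 2 to compound 3 (0.12 log units; within the scatter) in this assay and is the first one-place reading at this position: the two compounds cannot be told apart here. The step to 4-(hydroxycarbamoyl)benzyl in place of 4-(hydroxycarbamoyl)phenyl on the nitrogen gives a 1.1-fold higher number from compound 1 to compound 3 (0.05 log units; within the scatter) and likewise separates nothing, so neither change moves the number beyond the scatter. No measurement at hand explains either result.

From the compounds shown here alone, whether any change at this position can move the number beyond the scatter stays open. A carboxylic acid in place of hydroxycarbamoyl, or a longer chain carrying hydroxycarbamoyl on the same aromatic carbon, would test this.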